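Urea to carbamate on the acylsulfonamide side chain

This account rests on a few compounds, and the source may have more. Where it says the series, first, only, none or still open, it means among the compounds named here.

Two compounds of the series have been run in a physicochemical assay for permeability, using PAMPA, at pH 7.4; a lower number here means that the compound crosses the layer more slowly, a higher number that the compound crosses the layer faster. Compound 1 `CC(C)(C)CNCCS(=O)(=O)NC(=O)c1ccc(Nc2nc(NC3(c4ccc(Cl)cc4)CC3)nc(OCC(F)(F)F)n2)cc1` gives 651 nm/s. Among the measured compounds shown here, compound 2 `CC(C)NC(=O)NCCS(=O)(=O)NC(=O)c1ccc(Nc2nc(NC3(c4ccc(Cl)cc4)CC3)nc(OCC(F)(F)F)n2)cc1` gives 45 nm/s and stands lowest of the two; the only step measured so far, a 14-fold lower number from compound 1 to compound 2 (1.16 log units; beyond the scatter), is a large drop. Compound 3 `COC(=O)NCCS(=O)(=O)NC(=O)c1ccc(Nc2nc(NC3(c4ccc(Cl)cc4)CC3)nc(OCC(F)(F)F)n2)cc1` keeps the core of compound 2 and differs from it only by methoxy in place of isopropylamino on a carbonyl carbon. For the measured compounds named here, no measured step shows this exact change; the measured drop bears on it only in that both changes sit on the same side chain, and that drop was large. For compound 3 the expected step is a 2.2-fold higher number from compound 2 to compound 3 (0.35 log units; beyond the scatter), a moderate rise, with the scatter leaving room for no change at all. Compound 3 is therefore estimated at 100 nm/s, within a range from 35 nm/s to 280 nm/s.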

Compound 3, apparent permeability: 39 nm/s
The estimate for compound 3 lay 2.6-fold (0.41 log units) above the measured number, and the stated range covers the measured number.
By their numbers in this assay, from the lowest: compounds 3 and 2 (each within the scatter of the next); then compound 1.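

In this assay, methoxy in place of isopropylamino on a carbonyl carbon gives a 1.2-fold lower number from compound 2 to compound 3 (0.06 log units; within the scatter) and so does not separate the two groups at this position, although isopropylamino brings 1 hydrogen-bond donor and methoxy 0 hydrogen-bond donors. Methoxycarbonyl in place of neopentyl on the amine nitrogen gives a 17-fold lower number from compound 1 to compound 3 (1.22 log units; beyond the scatter) as a large step, so the large step is no longer tied to isopropylcarbamoyl alone: the urea and the carbamate both sit far under the neopentyl amine. No measurement on hand explains either step.

Open, going by these compounds, is whether the large step goes with a carbonyl on that nitrogen or with the loss of neopentyl. An acetyl group and a plain ethyl group on the same nitrogen would separate these two readings.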